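A few compounds are considered here, and "the series" means these few. Any claim that something is new, unique, unknown or untested is made for them only; others in the source may bear on it.

Measured so far in a functional assay on NCI-H460 cells (Homo sapiens) for antiproliferative activity, read by MTT assay, with a stated time of 72 h; on this read-out higher numbers stand for weaker inhibition and lower numbers for stronger inhibition:
- compound 1 `O=C(Nc1ccc(Oc2ccnc3[nH]ccc23)cc1)c1cc2cccnc2n(-c2ccccc2)c1=O`: 380 nM
- compound 2 `O=C(Nc1ccc(Oc2ccnc3[nH]ccc23)cc1)c1cc2cccnc2n(-c2ccc(C(F)(F)F)cc2Cl)c1=O`: 1950 nM
- compound 3 `Cn1ccc2c(Oc3ccc(NC(=O)c4cc5cccnc5n(-c5ccccc5)c4=O)cc3)ccnc21`: 560 nM

Compound 3 holds the second highest of the three numbers. Its nearest neighbour is compound 1, and the step of a 1.5-fold higher number from compound 1 to compound 3 (0.17 log units; within the scatter) shows that the two are not separated. Compound 2 is furthest away and gives the higher number of that pair.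

Compound 4 `COc1ccc(-n2c(=O)c(C(=O)Nc3ccc(Oc4ccnc5c4ccn5C)cc3)cc3cccnc32)cc1` differs from compound 3 in one place: methoxy in place of hydrogen on an aromatic carbon. Among the measured compounds shown here, the only measured step that alters the phenyl on the aromatic nitrogen is a 5.1-fold higher number from compound 1 to compound 2 (0.71 log units; beyond the scatter), where a 2-chloro-4-(trifluoromethyl)phenyl entered; that step raised the number. The step from compound 1 to compound 3 touched a different position and stayed within scatter, so it says nothing about this change. A single methoxy is a smaller alteration than the disubstituted ring of compound 2, so for compound 4 a rise of the number in this assay is expected but a smaller one, a 1.6-fold higher number from compound 3 to compound 4 (0.21 log units; within the scatter), which may not clear the scatter. Compound 4 is therefore estimated at 900 nM, with a range from 350 nM to 2500 nM.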

Compound 4, half-maximal inhibitory concentration: 1920 nM
Beside the measured number, compound 4's estimate is 2.1-fold (0.33 log units) below it; low and high end bracket the measured number.
By their numbers in this assay, from the lowest: compounds 1 and 3 (each within the scatter of the next); then compounds 4 and 2 (each within the scatter of the next).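

In this assay, a single methoxy on the phenyl, para to a large group, is enough to produce a 3.4-fold higher number from compound 3 to compound 4 (0.54 log units; beyond the scatter). Among the compounds shown here, until now the only step at this ring was a 5.1-fold higher number from compound 1 to compound 2 (0.71 log units; beyond the scatter), which came from a disubstituted ring with hydrogen on the aromatic nitrogen, so the rise now also appears with one small group and with methyl on that nitrogen. No measurement at hand explains the rise.

From the compounds shown here alone, whether the phenyl to 4-methoxyphenyl step holds with hydrogen in place of that methyl remains open. Also open, going by these compounds, is whether a hydroxyl, an amine or a longer chain such as ethoxy in the same place would raise the number as well.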